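Cytotoxicity notes: cyclohexylamino to cyclopropylamino on the shared core

A few compounds are considered here, and "the series" means these few. Any claim that something is new, unique, unknown or untested is made for them only; others in the source may bear on it.

Within the data shown here, compound 2 `OC[C@H]1O[C@@H](n2cnc3c(NC4CCCC4)nc(NC4CCCCC4)nc32)[C@H](O)[C@@H]1O` is the only member of this set with a number in an ADME assay on HEK-293T cells (Homo sapiens) for cytotoxicity, read by resazurin assay, with a stated time of 16 h (on this read-out higher numbers stand for weaker inhibition and lower numbers for stronger inhibition), where compound 2 gives 228000 nM. Compound 1 `OC[C@H]1O[C@@H](n2cnc3c(N4CCCCC4)nc(N4CCCCC4)nc32)[C@H](O)[C@@H]1O`, which carries the same core, has no reported result in this assay and is entered only as "not determined" (no result reported). Among the measured compounds shown here, compound 3 `OC[C@H]1O[C@@H](n2cnc3c(NCc4cccc5ccccc45)nc(NCCC(c4ccccc4)c4ccccc4)nc32)[C@H](O)[C@@H]1O`, which also carries the same core, is likewise entered only as "not determined" (no result reported), so compound 2 stands alone as the reference point and no step between measured compounds can be read. Compound 4 `OC[C@H]1O[C@@H](n2cnc3c(NC4CCCC4)nc(NC4CC4)nc32)[C@H](O)[C@@H]1O` has not been measured. Relative to compound 2, compound 4 carries the change (cyclopropyl in place of cyclohexyl on a nitrogen on an aromatic ring), the cyclohexylamino to cyclopropylamino exchange, while the substituent on the other nitrogen is unchanged. For the measured compounds named here, with no measured step anywhere to lean on, the change is treated as neutral for now. The step from compound 2 to compound 4 is expected to be a 1.1-fold higher number from compound 2 to compound 4 (0.04 log units; within the scatter), which is no step beyond the usual scatter, in no clear direction. For compound 4 in this assay the estimate is 250000 nM, with an expected range from 100000 nM to 600000 nM.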

Compound 4, half-maximal inhibitory concentration: > 500000 nM
Compound 4 gave a limit, no number; the forecaster's own chance of this, stated with the estimate: 30%; middle value at least 2.0-fold (0.30 log units) away from the limit.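

In this assay compound 4 gives > 500000 nM, which is a limit of the assay and not a number. Cyclopropyl in place of cyclohexyl on a nitrogen on an aromatic ring gives the first readable step in the series, an at least 2.1-fold higher number from compound 2 to compound 4 (0.34 log units; beyond the scatter), so this position does respond to the exchange, and the read-out moves towards weaker inhibition. The step has a lower bound only, and its full size stays unknown: the limit of > 500000 nM in this assay, at which 1 of the 4 values shown sits.

Steps involving compound 1 and compound 3 cannot be read, so the step from compound 2 to compound 4 stands alone as a single comparison. Open, from the compounds shown here alone, is what a straight butyl chain or a cyclobutyl group on this nitrogen would give in this assay, and whether the step holds with a different substituent on the other nitrogen.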